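From Compound 3 to Compound 4: One Ring Rearranged

A few compounds are considered here, and "the series" means these few. Any claim that something is new, unique, unknown or untested is made for them only; others in the source may bear on it.

Measured compounds and their values:
compound 1 `COc1ccc(NC(=O)[C@H]2CCCCN2C(=O)C2(c3ccc(Cl)cc3)CCCC2)cc1`: 5.01 nM
compound 2 `COc1ccc(NC(=O)[C@H]2CCCN2C(=O)C2(c3ccc(Cl)cc3)CCCC2)cc1`: 7.94 nM
compound 3 `O=C(Nc1cnc2[nH]ncc2c1)[C@H]1CCCN1C(=O)C1(c2cccc(Cl)c2)CCCC1`: 15.9 nM

All three were measured in an assay on isolated protein for inhibition of histone acetyltransferase p300 (Homo sapiens), with a stated time of 60 min; on this read-out higher numbers stand for weaker inhibition and lower numbers for stronger inhibition. Compound 3 gives the highest of the three numbers; compound 2 stands within the scatter of it, while compound 1 lies beyond the scatter, with the lower number. Compound 4 `O=C(Nc1ccc2[nH]nnc2c1)[C@H]1CCCN1C(=O)C1(c2cccc(Cl)c2)CCCC1` has not yet been measured. It differs from compound 3 in one place: a group of 9 heavy atoms (6 carbon, 3 nitrogen; one five-membered aromatic ring with 3 hetero atoms, one six-membered aromatic ring of carbon only) in place of a group of 9 heavy atoms (6 carbon, 3 nitrogen; one five-membered aromatic ring with 2 hetero atoms, one six-membered aromatic ring with 1 hetero atom), on an amide-type nitrogen. Among the compounds with values here, no pair of measured compounds shows this change, so the data give no direction for it. The step of a 1.3-fold higher number from compound 3 to compound 4 (0.10 log units; within the scatter) is therefore expected to be small, not beyond the scatter. Compound 4 is expected to give 20 nM, within a range from 6 nM to 63 nM.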

Compound 4, half-maximal inhibitory concentration: 20 nM
Estimate against measurement, compound 4: no gap at the digits printed, within the range that was stated.
By their numbers in this assay, from the lowest: compounds 1, 2, 3 and 4 (each within the scatter of the next, the first and the last beyond it).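

In this assay, the group with a six-membered aromatic ring of carbon only and a five-membered aromatic ring with 3 hetero atoms takes the place of the group with a six-membered aromatic ring with 1 hetero atom and a five-membered aromatic ring with 2 hetero atoms, giving a 1.3-fold higher number from compound 3 to compound 4 (0.10 log units; within the scatter). Within the data shown here, this is the first single-place step, and on this amide-type nitrogen the two arrangements of the same atoms cannot be told apart. No measurement shown offers an explanation for this result.

The compounds shown leave open how a simple pyridine ring or a carboxylic acid on this nitrogen would read out. They also leave open whether the same rearrangement would give a similar step on another core.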